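The source may hold more compounds than are shown below. What is called first, only, known or untested is meant among the compounds shown, and "the series" means these compounds.

Compound 2 `CCCc1nc(-c2ccccc2)c(CNCCN2CCN(c3ccc(Cl)cc3)CC2)o1` in an assay on HEK293 cells for inhibition of Voltage-dependent T-type calcium channel subunit alpha-1G (Homo sapiens), read by fluorescence, tested at 10 uM (a lower number here means less inhibition, a higher number more inhibition at the concentration tested (going by the name of the read-out)), gives 55.8%, the second highest of the three numbers to hand. Compound 3 `CCCc1nc(-c2ccccc2)c(CNCCCN2CCN(c3ccc(C)cc3)CC2)o1` gives 53.9% and compound 1 `CCCc1nc(-c2ccccc2)c(CNCCCN2CCN(c3ccc(F)cc3)CC2)o1` gives 62.5%; both gaps to compound 2 lie within the scatter. Going by the values given here, the only single-point step known is a number 8.6 percentage points lower from compound 1 to compound 3 (within the scatter), a change of the group on the aryl carbon of the phenylpiperazine, and it stayed within the scatter. Compound 4 `CCCc1nc(-c2ccccc2)c(CNCCN2CCN(c3ccc(OC)cc3)CC2)o1` differs from compound 2 by methoxy in place of chloro on an aromatic carbon. Among the compounds with values here, no measured step involves a methoxy group, so the expectation rests on that one small step: no change beyond the scatter in this assay is expected. Compound 4 is expected to give 52% (range 35% to 68%). The expected step is a number 3.8 percentage points lower from compound 2 to compound 4 (within the scatter), within the scatter.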

Compound 4, a percentage reported as inhibition, at one concentration (the size of the read-out at that concentration, not a potency): 51.5%
Compound 4: middle estimate off by 0.5 percentage points, on the high side; the range from low to high includes it.
By their numbers in this assay, from the lowest: compounds 4, 3, 2 and 1 (each within the scatter of the next, the first and the last beyond it).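

The exchange of chloro for methoxy gives a number 4.3 percentage points lower from compound 2 to compound 4 (within the scatter) in this assay, so a hydrogen-bond acceptor enters at this aromatic carbon without a step beyond the scatter. With a number 8.6 percentage points lower from compound 1 to compound 3 (within the scatter) as well, two different exchanges at this carbon now stay within the scatter, each in its own pair of compounds. No measurement bears on why this exchange behaves as it does.

The compounds shown leave open whether a carboxylic acid or an amine on this aromatic carbon would give a step beyond the scatter.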